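Halogen swap on the benzyl ring of a quinoline ether triazole

The source may report more compounds than this note shows. Statements on the series, on what has been measured and on what is new or still open speak of the compounds shown alone.

Three compounds have been measured in a functional assay on PC-3 cells (Homo sapiens) for inhibition, read by sulforhodamine B assay, with a stated time of 48 h; a higher number here means a weaker inhibitor of growth, a lower number a stronger inhibitor of growth:
compound 1 `Ic1ccc(Cn2cc(CCCOc3cccc4cccnc34)nn2)cc1` gives 24.7 ug/mL
compound 2 `Fc1ccc(Cn2cc(CCCOc3cccc4cccnc34)nn2)cc1` gives 20.1 ug/mL
compound 3 `Clc1ccc(Cn2cc(CCCOc3cccc4cccnc34)nn2)cc1` gives 3.6 ug/mL

Compound 3 has the lowest number of the three. The steps to it are a 6.9-fold lower number from compound 1 to compound 3 (0.84 log units; beyond the scatter) and a 5.6-fold lower number from compound 2 to compound 3 (0.75 log units; beyond the scatter), whereas between the other two there is a 1.2-fold lower number from compound 1 to compound 2 (0.09 log units; within the scatter). Compound 4 `Brc1ccc(Cn2cc(CCCOc3cccc4cccnc34)nn2)cc1` differs from compound 3 by bromo in place of chloro on an aromatic carbon. The steps iodo to chloro and fluoro to chloro bear on this change, and both were modest, but they run in no single direction across the halogens, so the direction for bromo is uncertain. For compound 4 a value of 8 ug/mL is estimated, in the range 3 ug/mL to 25 ug/mL. This estimate means a step of a 2.2-fold higher number from compound 3 to compound 4 (0.35 log units; beyond the scatter) is expected.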

Compound 4, concentration for 50% growth inhibition: 8.4 ug/mL
Compound 4: middle estimate off by 1.1-fold (0.02 log units), on the low side, within the range that was stated.
By their numbers in this assay, from the lowest: compound 3; then compound 4; then compounds 2 and 1 (each within the scatter of the next).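

With bromo in this place, compound 4 sits in the middle in this assay: there is a 2.3-fold higher number from compound 3 to compound 4 (0.37 log units; beyond the scatter), but also a 2.4-fold lower number from compound 2 to compound 4 (0.38 log units; beyond the scatter) and a 2.9-fold lower number from compound 1 to compound 4 (0.47 log units; beyond the scatter). The numbers therefore rise in the order chloro, bromo, iodo, and compound 2, with fluoro, goes against that order. Chloro stays the best of the four halogens here.

As far as these compounds go, whether a methoxy group or a nitrile at this place would give a number lower than that of compound 3 remains open. Nothing shown here explains the order of the halogens.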